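Exchanging 4-(trifluoromethyl)phenyl in compound 3

The source may hold more compounds than are shown below. What is called first, only, known or untested is meant among the compounds shown, and "the series" means these compounds.

In a functional assay on MCF7 cells (Homo sapiens) for inhibition, read by sulforhodamine B assay (a higher number here means a weaker inhibitor of growth, a lower number a stronger inhibitor of growth), compound 1 `FC(F)(F)c1ccc(-c2ccc(-c3ccc(-c4nc5ccccc5[nH]4)cc3)cc2)cc1` gives 41400 nM and compound 2 `Oc1ccc(-c2ccc(-c3ccc(-c4nc5ccccc5[nH]4)cc3)cc2)cc1` gives 30500 nM. Compound 3 `Oc1cccc2[nH]c(-c3ccc(-c4ccc(-c5ccc(C(F)(F)F)cc5)cc4)cc3)nc12` has the lowest number of the three, at 2310 nM. Compound 4 `COc1ccc(-c2ccc(-c3ccc(-c4nc5c(O)cccc5[nH]4)cc3)cc2)cc1OC` carries 3,4-dimethoxyphenyl in place of 4-(trifluoromethyl)phenyl on an aromatic carbon, para to a large group: 3,4-dimethoxyphenyl in place of 4-(trifluoromethyl)phenyl on an aromatic carbon. For the measured compounds named here, two measured steps bear on this. Hydroxy added to the core gave an 18-fold lower number from compound 1 to compound 3 (1.25 log units; beyond the scatter), and compound 4 keeps that hydroxy. Hydroxy in place of trifluoromethyl, the one measured change within the departing group, gave a 1.4-fold lower number from compound 1 to compound 2 (0.13 log units; within the scatter). No step beyond the scatter is therefore expected in this assay, although this rests on that single step. The expected change is a 1.2-fold higher number from compound 3 to compound 4 (0.08 log units; within the scatter). Compound 4 is estimated at 2800 nM, with an expected range of 1000 nM to 8000 nM.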

Compound 4, concentration for 50% growth inhibition: 190 nM
Beside the measured number, compound 4's estimate is 15-fold (1.17 log units) above it, outside the stated range (below it).
By their numbers in this assay, from the lowest: compound 4; then compound 3; then compounds 2 and 1 (each within the scatter of the next).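

In this assay, 3,4-dimethoxyphenyl in place of 4-(trifluoromethyl)phenyl gave a 12-fold lower number from compound 3 to compound 4 (1.08 log units; beyond the scatter), so this position on an aromatic carbon can move the number well beyond the scatter. The earlier change at this end of the molecule, a 1.4-fold lower number from compound 1 to compound 2 (0.13 log units; within the scatter), had not shown this, though it was a different exchange on a core without the hydroxy. No measurement shown accounts for the new step.

Going by these compounds, whether one methoxy alone would give the same step, or an amine or a carboxylic acid at this position, remains open. So does whether 3,4-dimethoxyphenyl would act alike on the core of compound 1 .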